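The compounds below may be only part of what the source reports. "The series", "measured", "known", "first", "only" and "open" are said of these compounds alone.

Compound 1 `CCCCC[Se]c1nc(NCc2ccc(SC)cc2)c2ccccc2n1` inhibits growth in a functional assay on CCRF-CEM cells (Homo sapiens) for cytotoxicity, read by MTT assay, with a stated time of 72 h (on this read-out higher numbers stand for weaker inhibition of growth and lower numbers for stronger inhibition of growth), with a value of 35000 nM. Compound 2 `CSc1ccc(CNc2nc([SeH])nc3ccccc23)cc1` gives 71900 nM in this assay, and the change between them, (hydrogen in place of pentyl on a selenium), brought a 2.1-fold higher number from compound 1 to compound 2 (0.31 log units; beyond the scatter). Compound 3 `CCCCC[Se]c1nc(NCc2ccccc2)c2ccccc2n1` gives 34500 nM; its core differs from that of compound 1 by hydrogen in place of methylsulfanyl on an aromatic carbon, a change that brought a 1.0-fold lower number from compound 1 to compound 3 (0.01 log units; within the scatter). Compound 4 `[SeH]c1nc(NCc2ccccc2)c2ccccc2n1` has not yet been measured. It differs from compound 3 by hydrogen in place of pentyl on a selenium, the same change that led from compound 1 to compound 2, made at the same place. Because that earlier change brought a 2.1-fold higher number from compound 1 to compound 2 (0.31 log units; beyond the scatter), a step of similar size is expected here, estimated as a 2.0-fold higher number from compound 3 to compound 4 (0.31 log units; beyond the scatter). On that basis compound 4 is expected to give about 70000 nM in this assay, most likely between 35000 nM and 140000 nM.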

Compound 4, concentration for 50% growth inhibition: > 100000 nM
Compound 4: only a limit was reported; the forecaster's own chance of this, stated with the estimate: 15%; middle value at least 1.4-fold (0.15 log units) away from the limit.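

Hydrogen in place of pentyl on a selenium gave an at least 2.8-fold higher number from compound 3 to compound 4 (0.46 log units; beyond the scatter) in this assay, which points the same way as the step on the core of compound 1. On these data alone, the value of compound 4, > 100000 nM, is a limit of the assay and not a number, so the direction carries over, but whether the size of the step does stays open. Hydrogen in place of methylsulfanyl gave an at least 1.3-fold higher number from compound 2 to compound 4 (0.14 log units; that floor lies within the scatter), and as that floor lies within the scatter, this step shows no clear change.

The compounds shown leave open how a shorter chain such as ethyl, or a longer chain such as octyl, on the selenium would behave. They also leave open what an amine or a carboxylic acid in place of methylsulfanyl would do.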